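The source may hold more compounds than are shown below. What is called first, only, known or untested is meant among the compounds shown, and "the series" means these compounds.

Measured so far:
- Compound 1 `COc1ccccc1-c1cc(=O)[nH]n1-c1ccc(C(=O)NNC(=O)CO[N+](=O)[O-])cc1` — 66.9 ug/mL in a functional assay on aorta (Rattus norvegicus, strain Wistar) for inhibition; on this read-out higher numbers stand for an effect only at larger amounts of compound and lower numbers for an effect already at smaller amounts
- Compound 2 `O=C(CO[N+](=O)[O-])NNC(=O)c1ccc(-n2[nH]c(=O)cc2-c2ccc(Cl)cc2)cc1` — 21.3 ug/mL in this assay

For the measured compounds named here, compound 1 stands at the highest of the two numbers in this assay; the only measured neighbour is compound 2, and the move a 3.1-fold lower number from compound 1 to compound 2 (0.50 log units; beyond the scatter) came with a different aryl group on the shared core, not with any change at the site now in question. Compound 3 `CCOC(=O)c1c(-c2ccccc2OC)n(-c2ccc(C(=O)NNC(=O)CO[N+](=O)[O-])cc2)[nH]c1=O` keeps everything in compound 1 except that it carries ethoxycarbonyl in place of hydrogen on an aromatic carbon. Going by the values given here, no measured step touches this position, so the one step on record gives no direct guide to what an added ethoxycarbonyl does here. With nothing to point up or down, the expectation for compound 3 is a move of about a 1.1-fold lower number from compound 1 to compound 3 (0.05 log units; within the scatter), that is, no step beyond the usual scatter. Compound 3 is therefore estimated at 60 ug/mL in this assay, with a range from 25 ug/mL to 160 ug/mL.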

Compound 3, half-maximal effective concentration: 63.1 ug/mL
For compound 3 the middle estimate is 1.1-fold (0.02 log units) below the measured one, and the stated range covers the measured number.
By their numbers in this assay, from the lowest: compound 2; then compounds 3 and 1 (each within the scatter of the next).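

In this assay, ethoxycarbonyl in place of hydrogen on this aromatic carbon gives a 1.1-fold lower number from compound 1 to compound 3 (0.03 log units; within the scatter) and so leaves the read-out within the usual scatter. The carbon next to the ring atom that bears a 2-methoxyphenyl group therefore takes on a group of 5 heavy atoms with no step beyond the scatter, something the earlier pair, which differs only in the aryl group, could not show. Nothing on hand says why the number stays within the scatter here. From the compounds shown here alone, whether ethoxycarbonyl behaves the same way with the 4-chlorophenyl group of compound 2 remains open. Also open, going by these compounds, is what a carboxylic acid, an amine or a longer chain such as butoxycarbonyl would do on this same carbon.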